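A few compounds are considered here, and "the series" means these few. Any claim that something is new, unique, unknown or untested is made for them only; others in the source may bear on it.

Compound 3 `CC(C)(C1OCC(C/C=C\CCC(=O)O)C(c2cccnc2)O1)S(=O)(=O)c1ccccc1` stands second highest of the three numbers in an assay for inhibition of Thromboxane-A synthase (Homo sapiens), using microsomes (on this read-out higher numbers stand for weaker inhibition and lower numbers for stronger inhibition), where compound 3 gives 40 nM. Its nearest neighbour is compound 1 `CC(C)(Oc1ccccc1)C1OCC(C/C=C\CCC(=O)O)C(c2cccnc2)O1`, which in this assay gives 52 nM; the furthest is compound 2 `Cc1ccc(SC(C)(C)C2OCC(C/C=C\CCC(=O)O)C(c3cccnc3)O2)c([N+](=O)[O-])c1`, which in this assay gives 30 nM. Compound 4 `CC(C)(Cc1ccc(F)cc1C#N)C1OCC(C/C=C\CCC(=O)O)C(c2cccnc2)O1` carries a group of 10 heavy atoms (8 carbon, 1 nitrogen, 1 fluorine; one six-membered aromatic ring of carbon only) in place of a group of 9 heavy atoms (6 carbon, 2 oxygen, 1 sulfur; one six-membered aromatic ring of carbon only), on a saturated chain carbon bound to two saturated chain carbons and a saturated ring carbon. Every measured step at that position stays within the scatter: a 1.7-fold lower number from compound 1 to compound 2 (0.24 log units; within the scatter), a 1.3-fold lower number from compound 1 to compound 3 (0.11 log units; within the scatter) and a 1.3-fold higher number from compound 2 to compound 3 (0.12 log units; within the scatter). Each exchange of the aromatic group on that chain carbon has left this assay essentially unchanged, so for compound 4 a step of no change at the digits printed from compound 3 to compound 4 (within the scatter) is expected, nothing beyond the scatter. Compound 4 is therefore estimated at 40 nM in this assay, with a range of 15 nM to 110 nM.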

Compound 4, half-maximal inhibitory concentration: < 10 nM
Compound 4: no number, only a limit (the forecaster's own chance of this, stated with the estimate: 3%); at least 4.0-fold (0.60 log units) between middle value and limit.
By their numbers in this assay, from the lowest: compounds 2, 3 and 1 (each within the scatter of the next). At a limit, below all of these: compound 4.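

Compound 4 gives a limit, not a number, in this assay: the limit of < 10 nM in this assay, at which 1 of the 4 values shown sits. The saturated chain carbon bound to two saturated chain carbons and a saturated ring carbon now proves sensitive to exchange, with an at least 4.0-fold lower number from compound 3 to compound 4 (0.60 log units; beyond the scatter), an at least 3.0-fold lower number from compound 2 to compound 4 (0.47 log units; beyond the scatter) and an at least 5.2-fold lower number from compound 1 to compound 4 (0.71 log units; beyond the scatter). Among the compounds shown, only the entering group of compound 4 moves this read-out beyond the scatter.

On these data alone, how far compound 4 lies past its limit remains unknown, so each step has no fixed size. Also open, as far as these compounds go, are the separate contributions of the nitrile and the fluorine, and the outcome with an amine at this place.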